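Aryl urea change from compound 3 to compound 4

The compounds below may be only part of what the source reports. "The series", "measured", "known", "first", "only" and "open" are said of these compounds alone.

Compound 1 `COc1cccc(S(=O)(=O)Nc2cccc(-c3nc(-c4ccc(NC(=O)c5cccnc5)cc4Cl)no3)c2)c1`: in a functional assay on MDA-MB-231 cells (Homo sapiens) for antiproliferative activity, read by MTT assay, with a stated time of 72 h (on this read-out lower numbers stand for stronger inhibition and higher numbers for weaker inhibition), compound 1 gives > 10000 nM, a limit of the assay.
Compound 2 `COc1ccc(NC(=O)Nc2cccc(-c3nc(-c4ccc(NC(=O)c5cccnc5)cc4Cl)no3)c2)cc1C(F)(F)F`: in this assay compound 2 gives 1700 nM.
Compound 3 `C#Cc1ccc(NC(=O)Nc2cccc(-c3nc(-c4ccc(NC(=O)c5cccnc5)cc4Cl)no3)c2)cc1`: in this assay compound 3 gives > 10000 nM, again a limit.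

Compound 3 therefore sits at the limit of > 10000 nM in this assay, at which 2 of the 3 values shown sit, with no number of its own. The step that the two limits leave unreadable from compound 1 to compound 3 cannot be read. The step of an at least 5.8-fold higher number from compound 2 to compound 3 (0.76 log units; beyond the scatter) shows the 4-ethynylphenyl urea to be weaker than the 4-methoxy-3-(trifluoromethyl)phenyl urea.

Compound 4 `CC(=O)Nc1ccc(NC(=O)Nc2cccc(-c3nc(-c4ccc(NC(=O)c5cccnc5)cc4Cl)no3)c2)cc1Cl` differs from compound 3 by 4-acetamido-3-chlorophenyl in place of 4-ethynylphenyl on an amide-type nitrogen. Among the measured compounds shown here, the only measured step bearing on this change is an at least 5.8-fold higher number from compound 2 to compound 3 (0.76 log units; beyond the scatter), in which the substituted phenyl urea gave the lower number. The entering group carries one hydrogen-bond donor, one hydrogen-bond acceptor and a chlorine, and so resembles compound 2 more than compound 3 in its counted features. A move back toward the range of compound 2 is expected, that is a lower number, though a further limit remains possible. For compound 4 the expected step is an at least 2.8-fold lower number from compound 3 to compound 4 (0.45 log units; beyond the scatter). Compound 4 is estimated at 3500 nM, between 900 nM and 12000 nM.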

Compound 4, half-maximal inhibitory concentration: > 10000 nM
Compound 4: a limit, no number; the forecaster's own chance of this, stated with the estimate: 35%; middle value at least 2.8-fold (0.45 log units) from the limit.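

In this assay compound 4 also ends at a limit of the assay, so the step from compound 3 cannot be read. Among the compounds shown here, the one readable step is an at least 5.8-fold higher number from compound 2 to compound 4 (0.76 log units; beyond the scatter), so on this amide-type nitrogen the 4-acetamido-3-chlorophenyl group, with its hydrogen-bond donor, hydrogen-bond acceptor and chlorine, does not hold the level of compound 2. Compound 2 remains the only urea shown with a number of its own, and the limit is now the most common result in the series: the limit of > 10000 nM in this assay, at which 3 of the 4 values shown sit.

As far as these compounds go, it remains open whether the methoxy or the trifluoromethyl group of compound 2 accounts for its lower number, which a phenyl urea carrying only one of the two would test. Also open, from the compounds shown here alone, is how a phenyl urea bearing an amine or a carboxylic acid would read in this assay.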